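Pyrimidin-4-yl for Phenyl at the Limit of Measurability

The compounds below may be only part of what the source reports. "The series", "measured", "known", "first", "only" and "open" are said of these compounds alone.

Compound 1, `NC(=O)c1c(NC(=O)c2ccc(C(F)(F)F)cc2)sc2c1CCN(Cc1c(Cl)cccc1Cl)C2`, gives > 50000 nM in a functional assay on HeLa cells (Homo sapiens) for antiproliferative activity, with a stated time of 24 h; a higher number here means a weaker inhibitor, a lower number a stronger inhibitor.
Compound 2, `NC(=O)c1c(NC(=O)c2ccccc2F)sc2c1CCN(Cc1cccc(Cl)c1)C2`, gives 49500 nM in this assay.
Compound 3, `NC(=O)c1c(NC(=O)c2ccccc2)sc2c1CCN(C(=S)Nc1ccccc1Cl)C2`, gives > 50000 nM in this assay.

Compound 3 stands only at a limit of this assay, not at a measured number; the limit of > 50000 nM in this assay, at which 2 of the 3 values shown sit, shows how common this outcome is among the compounds shown. Going by the values given here, compound 2 is the single compound with an actual value, and that value sits close to the same limit.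

Compound 4, `NC(=O)c1c(NC(=O)c2ccncn2)sc2c1CCN(C(=S)Nc1ccccc1Cl)C2`, differs from compound 3 by pyrimidin-4-yl in place of phenyl on a carbonyl carbon. Among the compounds with values here, no measured pair shows the effect of this change, so compound 4 is expected to remain near the limit, with a step that the limit leaves unreadable from compound 3 to compound 4 not beyond the scatter. Compound 4 is therefore estimated at 60000 nM, between 20000 nM and 200000 nM.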

Compound 4, half-maximal inhibitory concentration: > 50000 nM
Compound 4: only a limit was reported; the forecaster's own chance of this, stated with the estimate: 80%; the middle value lies beyond the limit too.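

Going by these compounds alone, compound 3 and compound 4 both stand only at a limit in this assay, so no step between them can be read: the limit of > 50000 nM in this assay, at which 3 of the 4 values shown sit. The compounds shown leave open whether pyrimidin-4-yl in place of phenyl on a carbonyl carbon changes activity at all.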